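This account rests on a few compounds, and the source may have more. Where it says the series, first, only, none or still open, it means among the compounds named here.

Notes on the series in a functional assay on HepG2 cells (Homo sapiens) for inhibition, read by MTT assay; a lower number here means a stronger inhibitor, a higher number a weaker inhibitor. Here compound 1 (`COc1cc2ncnc(Nc3ccc(NC(=O)c4cccc(C(F)(F)F)c4)cc3)c2cc1OC`) gives 83000 nM. Compound 2 (`COc1cc2ncnc(Nc3ccc(NC(=O)c4ccc(C(F)(F)F)cc4)cc3)c2cc1OC`) reads > 100000 nM, which is a limit of the assay and not a number. Going by the values given here, the only measured step is an at least 1.2-fold higher number from compound 1 to compound 2 (0.08 log units; that floor lies within the scatter). It exchanges 3-(trifluoromethyl)phenyl for 4-(trifluoromethyl)phenyl on a carbonyl carbon, and it gives only a floor, since one end of it is a limit.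

Compound 3 (`COc1cc2ncnc(Nc3ccc(NC(=O)c4c(F)cccc4F)cc3)c2cc1OC`) keeps the shared core and the amide but changes the group on the carbonyl carbon: 2,6-difluorophenyl in place of 4-(trifluoromethyl)phenyl on a carbonyl carbon. In words, 2,6-difluorophenyl stands in place of 4-(trifluoromethyl)phenyl. Among the compounds with values here, that step is the only guide, as it concerns the same place, but no measured compound carries the entering group. With compound 1 at 83000 nM, compound 3 is expected to stay at the weak end of this assay, with no clear move beyond the scatter. The expected step is an at least 1.3-fold lower number from compound 2 to compound 3 (0.12 log units; that floor lies within the scatter), at most a slightly lower number, and a second limit reading remains quite possible. For compound 3 the estimated value is 75000 nM, with an expected range of 30000 nM to 100000 nM.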

Compound 3, half-maximal inhibitory concentration: 17000 nM
Beside the measured number, compound 3's estimate is 4.4-fold (0.64 log units) above it, outside the stated range (below it).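

In this assay, going by these compounds alone, this exchange on the carbonyl carbon shows that the group at this place can move the number beyond the scatter, which the one earlier step, with its floor within the scatter, could not show: 2,6-difluorophenyl in place of 3-(trifluoromethyl)phenyl gives a 4.9-fold lower number from compound 1 to compound 3 (0.69 log units; beyond the scatter). In place of 4-(trifluoromethyl)phenyl, the same entering group gives an at least 5.8-fold lower number from compound 2 to compound 3 (0.76 log units; beyond the scatter). That second size is only a floor because compound 2 stands at a limit of the assay and not at a number: the limit of > 100000 nM in this assay, at which 1 of the 3 values shown sits.

The compounds shown do not separate the entry of the two fluorines from the departure of the trifluoromethyl group, and a plain phenyl or a phenyl carrying a single fluorine on the carbonyl carbon would bear on that. Also open, as far as these compounds go, is how the number moves with a group of another kind at this place, such as a phenyl carrying an amine or a carboxylic acid, so the reading rests on these three compounds alone.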